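Hydroxy for Fluoro on the Benzylamine of Compound 1

The source may hold more compounds than are shown below. What is called first, only, known or untested is meant among the compounds shown, and "the series" means these compounds.

Measured so far in a functional assay on SW-620 cells (Homo sapiens) for inhibition, read by MTT assay, with a stated time of 72 h; a higher number here means a weaker inhibitor, a lower number a stronger inhibitor:
Compound 1 `COc1cc(Oc2cccc(Nc3ccccc3)c2)cc(OC)c1CNCc1ccc(F)cc1` gives 6770 nM.
Compound 2 `COc1cc(Oc2cccc(Nc3ccccc3)c2)cc(OC)c1CNCc1ccc(C)cc1` gives 11800 nM.
Compound 3 `COc1cc(Oc2cccc(Nc3ccccc3)c2)cc(OC)c1CNC1CC1` gives only a limit of this assay, > 20000 nM.

Compound 1 holds the lowest of the two numbers, and compound 2 sits within the scatter of it, as a 1.7-fold higher number from compound 1 to compound 2 (0.24 log units; within the scatter) shows for methyl in place of fluoro on an aromatic carbon. Compound 4 `COc1cc(Oc2cccc(Nc3ccccc3)c2)cc(OC)c1CNCc1ccc(O)cc1` differs from compound 1 by hydroxy in place of fluoro on an aromatic carbon. Going by the values given here, the one step at the same place is a 1.7-fold higher number from compound 1 to compound 2 (0.24 log units; within the scatter), and it stayed within the scatter. The step of an at least 2.9-fold higher number from compound 1 to compound 3 (0.47 log units; beyond the scatter) removed the whole 4-fluorobenzyl, so it says less about this change. A small step is therefore expected, at most a modest weakening. Compound 4 is estimated at 9000 nM, from 3500 nM to 25000 nM, an expected 1.3-fold higher number from compound 1 to compound 4 (0.12 log units; within the scatter).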

Compound 4, half-maximal inhibitory concentration: 7940 nM
Compound 4: middle estimate off by 1.1-fold (0.05 log units), on the high side; measured number inside the range.
By their numbers in this assay, from the lowest: compounds 1, 4 and 2 (each within the scatter of the next). At a limit, above all of these: compound 3.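

In this assay, a hydrogen-bond donor and acceptor can enter at this position without separating the compounds: hydroxy for fluoro gives a 1.2-fold higher number from compound 1 to compound 4 (0.07 log units; within the scatter), and hydroxy for methyl gives a 1.5-fold lower number from compound 2 to compound 4 (0.17 log units; within the scatter). Exchanging cyclopropyl for 4-hydroxybenzyl on the amine nitrogen gives an at least 2.5-fold lower number from compound 3 to compound 4 (0.40 log units; beyond the scatter), a floor beyond the scatter, whereas the floor in an at least 1.6-fold higher number from compound 2 to compound 3 (0.22 log units; that floor lies within the scatter) stays within it. Compound 3 gives only a limit, not a number: the limit of > 20000 nM in this assay, at which 1 of the 4 values shown sits.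

On these data alone, whether a carboxylic acid or an amine at this position would stay level with fluoro, methyl and hydroxy remains open. So does the effect of a longer chain in place of the benzyl.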